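The 3-fluorobenzyl arm and the methyl that replaces it

The source may hold more compounds than are shown below. What is called first, only, known or untested is meant among the compounds shown, and "the series" means these compounds.

Compound 3 `O=c1ccc(-c2ccc3cn[nH]c3c2)cn1Cc1cccc(F)c1` holds the lowest number of the two measured values in an assay for inhibition of MAP kinase-interacting serine/threonine-protein kinase 1 (Homo sapiens), read by luminescence and ADP-Glo, with a stated time of 2 h (on this read-out higher numbers stand for weaker inhibition and lower numbers for stronger inhibition), where compound 3 gives 74 nM. Its nearest neighbour is compound 2 `Nc1cccc(Cn2cc(-c3ccc4cn[nH]c4c3)ccc2=O)c1`, which in this assay gives 287 nM, and the two are separated by a 3.9-fold lower number from compound 2 to compound 3 (0.59 log units; beyond the scatter). Compound 1 `O=C(N1CCOCC1)n1cc(-c2ccc3cn[nH]c3c2)ccc1=O` carries a (morpholin-4-yl)carbonyl group on the aromatic nitrogen in place of a benzyl group. In this assay compound 1 reaches only a limit, > 2000 nM, which is the limit of > 2000 nM in this assay, at which 1 of the 3 values shown sits. Both benzyl replacements produced large movements: an at least 6.9-fold lower number from compound 1 to compound 2 (0.84 log units; beyond the scatter) and an at least 27-fold lower number from compound 1 to compound 3 (1.43 log units; beyond the scatter).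

Compound 4 `Cn1cc(-c2ccc3cn[nH]c3c2)ccc1=O` differs from compound 3 by hydrogen in place of 3-fluorophenyl on a saturated chain carbon bound to an aromatic nitrogen. The measured steps all bear on this change in the same sense: the arm that disappears here is the one whose arrival produced the large steps away from compound 1. Its loss is therefore expected to raise the number, with a step estimated at a 20-fold higher number from compound 3 to compound 4 (1.31 log units; beyond the scatter). Compound 1, which has no such arm, sits at the limit of > 2000 nM in this assay, at which 1 of the 3 values shown sits, so compound 4 may also end up beyond the measurable range. Compound 4 is expected to give about 1500 nM in this assay, within 400 nM to 6000 nM.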

Compound 4, half-maximal inhibitory concentration: > 2000 nM
Compound 4 was reported as a limit; the forecaster's own chance of this, stated with the estimate: 35%; middle value at least 1.3-fold (0.12 log units) from the limit.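

With methyl on the aromatic nitrogen, the activity seen with the benzyl arms in this assay is lost: the change gives an at least 27-fold higher number from compound 3 to compound 4 (1.43 log units; beyond the scatter), and the arm carrying the amino group gives a matching reading, an at least 6.9-fold higher number from compound 2 to compound 4 (0.84 log units; beyond the scatter). The earlier steps set these arms only against the (morpholin-4-yl)carbonyl group, which left open whether removing that group was enough for the gain; the steps to methyl show that, among these compounds, the substituted phenyl on the saturated chain carbon goes with the lower numbers, whether it carries fluoro or amino. Compound 4 is reported only as a limit, the same limit as compound 1, and the step between the two cannot be read: the limit of > 2000 nM in this assay, at which 2 of the 4 values shown sit.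

What the compounds shown leave open is how much of the arm is required, as nothing stands between methyl and the substituted benzyl groups, such as an unsubstituted benzyl or a short chain like ethyl. They also leave open whether a methoxy group or a carboxylic acid in place of the fluoro would hold the number of compound 3 or move it.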